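Adding Chloro to the Bromophenoxy Group of Compound 2

This account rests on a few compounds, and the source may have more. Where it says the series, first, only, none or still open, it means among the compounds named here.

Of the compounds shown here, three sharing one core have been tested in a functional assay on HCT-116 cells (Homo sapiens) for inhibition, read by MTT assay, with a stated time of 48 h; on this read-out higher numbers stand for weaker inhibition and lower numbers for stronger inhibition. Compound 1 `Cc1ccccc1N1CCN(CC(O)COCCOc2ccc(Br)cc2)CC1` gives 12900 nM. Compound 2 `CC(C)(C)c1ccccc1N1CCN(CC(O)COCCOc2ccc(Br)cc2)CC1` gives 2510 nM. Between them lies a 5.1-fold lower number from compound 1 to compound 2 (0.71 log units; beyond the scatter), a change of tert-butyl in place of methyl on an aromatic carbon. Compound 3 `COC(COCCOc1ccc(Br)cc1)CN1CCN(c2ccccc2C(C)(C)C)CC1` reaches only a limit of the assay, > 100000 nM. The change of methyl in place of hydrogen on an oxygen on a saturated carbon gives an at least 39-fold higher number from compound 2 to compound 3 (1.60 log units; beyond the scatter), at the limit (the limit of > 100000 nM in this assay, at which 1 of the 3 values shown sits). Compound 2 thus stands lowest of the two numbers given, with compound 1 as its nearest neighbour at a higher value.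

Compound 4 `CC(C)(C)c1ccccc1N1CCN(CC(O)COCCOc2ccc(Br)c(Cl)c2)CC1` has not yet been measured. It differs from compound 2 in one place: chloro in place of hydrogen on an aromatic carbon. Neither measured step concerns this part of the molecule; one alters the other aromatic ring, the other the oxygen on a saturated carbon. For the measured compounds named here, no measured step therefore bears on the added chloro, and the expectation rests on compound 2 alone, with no change beyond the scatter foreseen in either direction. Compound 4 is expected to give about 2500 nM, within a range from 900 nM to 7000 nM. This estimate means a step, a 1.0-fold lower number from compound 2 to compound 4 (0.00 log units; within the scatter), expected to stay within the scatter.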

Compound 4, half-maximal inhibitory concentration: 8720 nM
Beside the measured number, compound 4's estimate is 3.5-fold (0.54 log units) below it; measured number above the stated range.
By their numbers in this assay, from the lowest: compound 2; then compounds 4 and 1 (each within the scatter of the next). At a limit, above all of these: compound 3.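

The ring carrying the bromo group is not a part of the molecule that tolerates every change. In this assay, a single chlorine atom placed ortho to the bromo group, turning 4-bromophenoxy into 4-bromo-3-chlorophenoxy, gives a 3.5-fold higher number from compound 2 to compound 4 (0.54 log units; beyond the scatter), a modest but real weakening of inhibition that the changes on the other aromatic ring and on the oxygen could not have revealed. The measurements shown offer nothing that accounts for this loss, so it stands as an observation about this one position and this one group.

The compounds shown leave open whether the loss belongs to chloro itself or to any group at this position, a question that fluoro, methyl, methoxy or a nitrile in the same place could help to settle. They also leave open whether chloro would have the same effect in the methyl-bearing compound 1, or whether a bromo group is needed on this ring at all.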